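A Dihydroxyphenyl Variant of Compound 3: Expected Cytotoxicity

This account rests on a few compounds, and the source may have more. Where it says the series, first, only, none or still open, it means among the compounds named here.

Of the compounds shown here, three sharing one core have been measured. Compound 1 `CN(C)CCn1cnnc1-c1cc(Oc2ccc(NC(=O)N/N=C/c3ccc(Cl)cc3Cl)cc2F)ccn1` gives 390 nM in a functional assay on HT-29 cells (Homo sapiens) for cytotoxicity, read by MTT assay, with a stated time of 72 h; on this read-out higher numbers stand for weaker inhibition and lower numbers for stronger inhibition. Compound 2 `CN(C)CCn1cnnc1-c1cc(Oc2ccc(NC(=O)N/N=C/c3ccccc3O[N+](=O)[O-])cc2F)ccn1` gives 950 nM in this assay, and compound 3 `CN(C)CCn1cnnc1-c1cc(Oc2ccc(NC(=O)N/N=C/c3ccc(F)cc3F)cc2F)ccn1` gives 960 nM in this assay. Among the three, compound 3 carries the largest number, although a 1.0-fold higher number from compound 2 to compound 3 (0.00 log units; within the scatter) leaves it indistinguishable from compound 2, while a 2.5-fold higher number from compound 1 to compound 3 (0.39 log units; beyond the scatter) separates it from compound 1. Compound 4 `CN(C)CCn1cnnc1-c1cc(Oc2ccc(NC(=O)N/N=C/c3ccc(O)c(O)c3)cc2F)ccn1` differs from compound 3 only in that (3,4-dihydroxyphenyl in place of 2,4-difluorophenyl on a carbon with a double bond to nitrogen). Both measured steps into compound 3 alter the group on that same carbon; one was modest and one fell within the scatter, and neither involved the 3,4-dihydroxyphenyl. Compound 4 is therefore expected to land near compound 3, with the step of a 1.3-fold higher number from compound 3 to compound 4 (0.10 log units; within the scatter) estimated small and uncertain in direction. The estimate for compound 4 is 1200 nM, within 400 nM to 4000 nM.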

Compound 4, half-maximal inhibitory concentration: 1890 nM
Beside the measured number, compound 4's estimate is 1.6-fold (0.20 log units) below it, and the stated range covers the measured number.
By their numbers in this assay, from the lowest: compound 1; then compounds 2, 3 and 4 (each within the scatter of the next).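

In this assay, among these compounds, 3,4-dihydroxyphenyl on this carbon, the first group here with hydrogen-bond donors, reads the same within the scatter as 2,4-difluorophenyl (a 2.0-fold higher number from compound 3 to compound 4 (0.29 log units; within the scatter)) and 2-(nitrooxy)phenyl (a 2.0-fold higher number from compound 2 to compound 4 (0.30 log units; within the scatter)). Only 2,4-dichlorophenyl stands apart from it (a 4.8-fold higher number from compound 1 to compound 4 (0.69 log units; beyond the scatter)), so the position tolerates this exchange of fluorine for hydroxyl without a reading beyond the scatter. Nothing available explains these numbers. The compounds shown leave open whether a single hydroxyl, a methoxy group, an amine or a carboxylic acid on this phenyl ring would read alike, and whether bromine would match chlorine.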